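The source may hold more compounds than are shown below. What is called first, only, known or untested is meant among the compounds shown, and "the series" means these compounds.

Measured so far in an ADME assay on liver for metabolic stability, with Liver microsome (Homo sapiens) as the target, read by LC-MS, using microsomes, with a stated time of 5 h; on this read-out higher numbers stand for fast clearance and lower numbers for slow clearance:
- compound 1, `C[C@]1(O)C[C@@](c2cccc(C(F)(F)F)c2)([C@H](O)c2ccccn2)C1`, gives 150 mL/min/kg
- compound 2, `O[C@H](c1ccccn1)[C@]1(c2ccc(C(F)(F)F)cc2)C[C@H](O)C1`, gives 50 mL/min/kg
- compound 3, `C[C@]1(O)C[C@](c2ccc(C(F)(F)F)cc2)([C@H](O)c2ccccn2)C1`, gives 33.3 mL/min/kg

Compound 3 and compound 2 share a core and differ in one place, (hydrogen in place of methyl on a saturated ring carbon). In this assay the step is a 1.5-fold higher number from compound 3 to compound 2 (0.18 log units; within the scatter), so the two values are read as equal. Compound 1 has the same atoms as compound 3 joined differently; the difference between the two cores is not broken down here. Compound 1 stands highest of the three in this assay, beyond the scatter above compound 2 and above compound 3.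

Compound 4, `O[C@H](c1ccccn1)[C@]1(c2cccc(C(F)(F)F)c2)C[C@@H](O)C1`, is not yet measured. It differs from compound 1 by hydrogen in place of methyl on a saturated ring carbon, the same change as from compound 3 to compound 2, at the same place in words. Among the compounds with values here, the step from compound 1 to compound 4 is expected to be a 1.1-fold higher number from compound 1 to compound 4 (0.05 log units; within the scatter), which rests on the within-scatter step a 1.5-fold higher number from compound 3 to compound 2 (0.18 log units; within the scatter) seen for the one earlier pair. Compound 4 is therefore estimated at 170 mL/min/kg in this assay, expected to fall between 85 mL/min/kg and 340 mL/min/kg.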

Compound 4, clearance: 50 mL/min/kg
Compound 4: the middle estimate sits 3.4-fold (0.53 log units) above what was measured; measured number below the stated range.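

In this assay hydrogen in place of methyl on a saturated ring carbon gives a 3.0-fold lower number from compound 1 to compound 4 (0.48 log units; beyond the scatter), so the change shifts the clearance number on the core of compound 1, whereas on the core of compound 3 the two values read as equal. Within the data shown here, this does not show which feature of the two cores separates the outcomes, nor how the change would behave on any further core, since only two pairs are available and no rule can rest on them. What can be said is that the change does not carry over as a constant step between these two cores, and that a step read on one core is a poor guide to the other: the same change on two cores in this assay, a 1.5-fold higher number (0.18 log units; within the scatter) from compound 3 to compound 2 and a 3.0-fold lower number (0.48 log units; beyond the scatter) from compound 1 to compound 4, 4.5-fold (0.65 log units) apart, beyond the scatter of two such steps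

The compounds shown leave open how clearance would respond to anything other than hydrogen or methyl on that ring carbon, such as an ethyl group, a longer chain or an amine. From the compounds shown here alone, it also remains open whether the same dependence on the core would appear with a nitrile in place of the trifluoromethyl group.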